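From compound 1 to compound 4: hydroxy to benzoyloxy

The source may report more compounds than this note shows. Statements on the series, on what has been measured and on what is new or still open speak of the compounds shown alone.

Compound 1 (`C=C1[C@H](OC(=O)c2ccccc2)[C@H]2[C@@H](OC(C)=O)[C@@H](C)C[C@]2(OC(C)=O)C(=O)[C@@H](C)/C=C/C(C)(C)C(=O)[C@H](O)[C@H]1OC(C)=O`) gives > 100000 nM in an ADME assay on NCI/ADR-RES cells (Homo sapiens) for cytotoxicity, read by MTT assay, with a stated time of 48 h (on this read-out higher numbers stand for weaker inhibition and lower numbers for stronger inhibition), and this is a limit, not a number. Compound 2 (`C=C1[C@H](OC(C)=O)[C@H]2[C@@H](OC(=O)c3ccccc3)[C@](C)(O)C[C@]2(O)C(=O)[C@@H](C)/C=C/C(C)(C)C(=O)[C@H](OC(C)=O)[C@H]1OC(=O)c1ccccc1`) gives > 100000 nM as a limit too. Compound 3 (`C=C1[C@H](OC(C)=O)[C@H]2[C@@H](OC(=O)c3ccccc3)[C@@H](C)C[C@]2(O)C(=O)[C@@H](C)/C=C/C(C)(C)C(=O)[C@H](O)[C@H]1OC(C)=O`) gives > 100000 nM as a limit too. Compound 1 thus stands with both others at the limit of > 100000 nM in this assay, at which 3 of the 3 values shown sit, and no measured step can be read from them. Compound 4 (`C=C1[C@H](OC(=O)c2ccccc2)[C@H]2[C@@H](OC(C)=O)[C@@H](C)C[C@]2(OC(C)=O)C(=O)[C@@H](C)/C=C/C(C)(C)C(=O)[C@H](OC(=O)c2ccccc2)[C@H]1OC(C)=O`) differs from compound 1 by benzoyl in place of hydrogen on an oxygen on a saturated carbon, hydroxy to benzoyloxy (benzoyl in place of hydrogen on an oxygen on a saturated carbon). For the measured compounds named here, with no measured step to scale from, the size expected in this assay is small, toward stronger inhibition or none beyond the scatter (estimated: an at least 1.2-fold lower number from compound 1 to compound 4 (0.09 log units; that floor lies within the scatter)). Compound 4 is expected at 80000 nM with 25000 nM to 200000 nM as its estimated range.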

Compound 4, half-maximal inhibitory concentration: > 100000 nM
Compound 4: a limit, no number; the forecaster's own chance of this, stated with the estimate: 65%; middle value at least 1.2-fold (0.09 log units) away from the limit.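

Compound 1 and compound 4 both stand at a limit in this assay and no step between them can be read: the limit of > 100000 nM in this assay, at which 4 of the 4 values shown sit.

The compounds shown leave open how large the hydroxy to benzoyloxy change really is, and whether any change on the shared core gives a readable number.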